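The compounds below may be only part of what the source reports. "The series", "measured", "known", "first", "only" and "open" are said of these compounds alone.

Of the compounds shown here, three that share one core have been measured so far in a physicochemical assay for solubility, in phosphate buffer, at pH 7.4 (a lower number here means a less soluble compound, a higher number a more soluble compound), for this series. Compound 1 (`CC(C)n1cc(-c2ccnc3[nH]c(C4CCNCC4)cc23)ccc1=O`) gives 910000 nM there, compound 2 (`CNC(=O)CN1CCC(c2cc3c(-c4ccc(=O)n(C(C)C)c4)ccnc3[nH]2)CC1`) gives 34000 nM there, and compound 3 (`CC(=O)N1CCC(c2cc3c(-c4ccc(=O)n(C(C)C)c4)ccnc3[nH]2)CC1`) gives 27000 nM there. Compound 3 therefore sits at the low end, level with the compound carrying (methylcarbamoyl)methyl (a 1.3-fold lower number from compound 2 to compound 3 (0.10 log units; within the scatter)) and far under the one with hydrogen on the ring amine nitrogen (a 34-fold lower number from compound 1 to compound 3 (1.53 log units; beyond the scatter)).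

Compound 4 (`CC(C)n1cc(-c2ccnc3[nH]c(C4CCN(CC(=O)N5CCCC5)CC4)cc23)ccc1=O`) has not yet been measured. It carries ((pyrrolidin-1-yl)carbonyl)methyl in place of acetyl on an amine nitrogen in a ring. Replacing the hydrogen on that nitrogen was a large step with either measured substituent, as with (methylcarbamoyl)methyl (a 27-fold lower number from compound 1 to compound 2 (1.43 log units; beyond the scatter)). Exchanging one substituent for the other, however, stayed within the scatter (a 1.3-fold lower number from compound 2 to compound 3 (0.10 log units; within the scatter)). Going by the values given here, the change now in view is again such an exchange, although no measured compound has a five-membered non-aromatic ring on this substituent, so the evidence is thin. On the strength of that exchange (a 1.3-fold lower number from compound 2 to compound 3 (0.10 log units; within the scatter)), no step beyond the scatter is expected. The expected step is a 1.1-fold lower number from compound 3 to compound 4 (0.03 log units; within the scatter) (an estimate only). For compound 4 the expected number in this assay is 25000 nM (estimated range 7000 nM to 90000 nM).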

Compound 4, solubility: 260000 nM
Compound 4: middle estimate off by 10-fold (1.02 log units), on the low side; the measured number lies above the stated range.
By their numbers in this assay, from the lowest: compounds 3 and 2 (each within the scatter of the next); then compound 4; then compound 1.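

In this assay, going by these compounds alone, exchanges on the amine nitrogen in a ring are not all level, as the one pair measured earlier had suggested: ((pyrrolidin-1-yl)carbonyl)methyl in place of acetyl gives a 9.6-fold higher number from compound 3 to compound 4 (0.98 log units; beyond the scatter). The change need not reach that nitrogen at all, since pyrrolidin-1-yl in place of methylamino on a carbonyl carbon, further out on the same substituent, gives a 7.6-fold higher number from compound 2 to compound 4 (0.88 log units; beyond the scatter), while replacing the hydrogen on the nitrogen with ((pyrrolidin-1-yl)carbonyl)methyl gives only a 3.5-fold lower number from compound 1 to compound 4 (0.54 log units; beyond the scatter), a smaller step than a 27-fold lower number from compound 1 to compound 2 (1.43 log units; beyond the scatter). Nothing shown here accounts for why the pyrrolidin-1-yl amide stands apart from compound 2 and compound 3.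

On these data alone, it remains open whether the higher number belongs to the five-membered ring itself or to any amide nitrogen carrying two carbon substituents, which a dimethylamino, piperidin-1-yl or morpholin-4-yl group on the same carbonyl carbon would separate. Also open, as far as these compounds go, is how a carboxylic acid or a longer chain between the amine nitrogen and the carbonyl would compare, and whether the step from compound 2 to compound 4 would hold on a different core.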